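This account rests on a few compounds, and the source may have more. Where it says the series, first, only, none or still open, it means among the compounds named here.

Measured compounds:
compound 1, `C[C@]1(O)CC(=O)O[C@H](CCc2ccc(Cl)cc2Cl)C1`, 26%
compound 2, `O=C1C[C@@H](O)C[C@@H](/C=C/c2ccc(Cl)cc2Cl)O1`, 4%
compound 3, `O=C1C[C@H](O)C[C@@H](/C=C/c2ccc(Cl)cc2Cl)O1`, 0%; 45% (2 entries)

In an assay for inhibition of 3-hydroxy-3-methylglutaryl-coenzyme A reductase (Rattus norvegicus), tested at 2 ug/mL (a higher number here means a stronger effect of the compound at the concentration tested, a lower number a weaker effect), compound 2 gives the lowest of the two single numbers; compound 1 gives a number well above it, beyond the scatter, and compound 3 has two entries that disagree widely (the several entries of compound 3 in this assay, 0%; 45% (2 entries)), although compounds 2 and 3 differ only in the configuration as drawn (the fact that compounds 2 and 3 differ only in the configuration as drawn). Compound 4, `C[C@]1(O)CC(=O)O[C@H](/C=C/c2ccc(Cl)cc2Cl)C1`, has not yet been tested in this assay. It differs from compound 2 by methyl in place of hydrogen on a saturated ring carbon. For the measured compounds named here, no pair that differs by this change has been measured here. The step of a number 8 percentage points higher from compound 2 to compound 4 (within the scatter) is expected to be small, in either direction, not beyond the scatter. Compound 4 is therefore estimated at 12%, with a range from 0% to 35%.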

Compound 4, a percentage reported as inhibition, at one concentration (the size of the read-out at that concentration, not a potency): 21%
Compound 4: middle estimate off by 9 percentage points, on the low side; the measured number falls inside the stated range.
By their numbers in this assay, from the lowest: compound 2; then compounds 4 and 1 (each within the scatter of the next).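

Methyl in place of hydrogen on this saturated ring carbon gives, in this assay, a number 17 percentage points higher from compound 2 to compound 4 (beyond the scatter), the first reading of this change at this position. The change therefore raises the read-out at the one concentration tested, though only modestly, and this says nothing about potency. Compound 3, which differs from compound 2 only in configuration, counsels caution about so modest a step: the several entries of compound 3 in this assay, 0%; 45% (2 entries).

The compounds shown leave open whether ethyl or a longer chain on this ring carbon would raise the read-out further, and whether methyl acts the same way in the configuration of compound 3.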